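From compound 2 to compound 4: nitro for methoxy

The source may report more compounds than this note shows. Statements on the series, on what has been measured and on what is new or still open speak of the compounds shown alone.

In a functional assay on HL-60 cells (Homo sapiens) for inhibition (on this read-out higher numbers stand for weaker inhibition and lower numbers for stronger inhibition), compound 1 `COc1cc(/C=C/c2ccc3ccccc3c2)cc([N+](=O)[O-])c1OC` is reported only as a limit, > 10000 nM. Compound 2 `COc1cc(/C=C\c2ccc3ccccc3c2)cc([N+](=O)[O-])c1OC` gives 340 nM and compound 3 `COc1cc(/C=C\c2ccc3ccccc3c2)cc(N)c1OC` gives 330 nM, two values within the scatter of each other. Compound 4 `COc1c([N+](=O)[O-])cc(/C=C\c2ccc3ccccc3c2)cc1[N+](=O)[O-]` differs from compound 2 by nitro in place of methoxy on an aromatic carbon, ortho to a methoxy group and meta to a nitro group. The double bond stays drawn Z, so the large step of an at least 29-fold lower number from compound 1 to compound 2 (1.46 log units; beyond the scatter), which goes with the fact that compounds 1 and 2 differ only in the configuration as drawn, is not repeated here. The nearest measured change on this ring, a 1.0-fold lower number from compound 2 to compound 3 (0.01 log units; within the scatter), lies within the scatter, but it leaves both methoxy groups in place. For the measured compounds named here, no measured step removes a methoxy, so the expectation is uncertain. A moderate estimated step of a 4.4-fold higher number from compound 2 to compound 4 (0.64 log units; beyond the scatter) is expected, toward weaker inhibition. The estimate in this assay for compound 4 is 1500 nM, with an expected range of 300 nM to 9000 nM.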

Compound 4, half-maximal inhibitory concentration: > 5000 nM
Compound 4 ended at the assay's limit; the forecaster's own chance of this, stated with the estimate: 15%; middle value at least 3.3-fold (0.52 log units) away from the limit.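

In this assay the replacement gives an at least 14-fold higher number from compound 2 to compound 4 (1.16 log units; beyond the scatter) with the double bond still drawn Z, so the core of compound 2 does not tolerate every change at this methoxy place. For compound 4 the reading of > 5000 nM is a limit and not a number. The change at the nitro place, a 1.0-fold lower number from compound 2 to compound 3 (0.01 log units; within the scatter) and within the scatter, stands against this, so the two ring places respond differently to the two replacements shown.

On these data alone, whether the loss goes with losing the methoxy or with gaining the nitro stays open. A hydroxyl or an ethoxy group at this place would separate the two.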